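This account rests on a few compounds, and the source may have more. Where it says the series, first, only, none or still open, it means among the compounds named here.

Measured in a functional assay on NCI-H1581 cells (Homo sapiens) for antiproliferative activity, read by CCK-8 assay, with a stated time of 72 h; on this read-out higher numbers stand for weaker inhibition and lower numbers for stronger inhibition:
compound 1 `COc1cc(OC)c(Cl)c(-c2ccc3c(NC(=O)c4ccc(N5CCN(C)CC5)cc4)n[nH]c3n2)c1Cl`: 1.7 nM
compound 2 `COc1cc(OC)c(Cl)c(-c2ccc3c(NC(=O)c4ccc(N5CCN(C6CCC6)CC5)cc4)n[nH]c3n2)c1Cl`: 2.3 nM
compound 3 `COc1cc(N2CCN(C)CC2)ccc1C(=O)Nc1n[nH]c2nc(-c3c(Cl)c(OC)cc(OC)c3Cl)ccc12`: 525 nM

Compound 2 cannot be told apart from compound 1, while compound 3 stands far higher than both. Compound 4 `COc1cc(OC)c(Cl)c(-c2ccc3c(NC(=O)c4ccc(N(C)C)cc4)n[nH]c3n2)c1Cl` has not been measured yet. Reaching it from compound 2 means putting dimethylamino in place of 4-cyclobutylpiperazin-1-yl on an aromatic carbon.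

Among the measured compounds shown here, two measured steps bear on this. Swapping methyl for cyclobutyl on the piperazine nitrogen gave a 1.4-fold higher number from compound 1 to compound 2 (0.13 log units; within the scatter), so that outer group could change freely in these two compounds. Adding a methoxy on an aromatic carbon gave a 310-fold higher number from compound 1 to compound 3 (2.49 log units; beyond the scatter), which shows that a single small change can move this series a long way. Neither step removes the whole piperazine, so neither measures this change directly.

A moderate loss is therefore expected in this assay, towards a higher number, though well short of the methoxy step. The expected size is a 4.3-fold higher number from compound 2 to compound 4 (0.64 log units; beyond the scatter). Compound 4 is estimated at 10 nM, with an expected range of 2 nM to 60 nM.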

Compound 4, half-maximal inhibitory concentration: 294 nM
Compound 4: middle estimate off by 29-fold (1.47 log units), on the low side; measured number outside the range, above it.
By their numbers in this assay, from the lowest: compounds 1 and 2 (each within the scatter of the next); then compounds 4 and 3 (each within the scatter of the next).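

Removing the whole 4-cyclobutylpiperazin-1-yl group in favour of dimethylamino, on this aromatic carbon para to a large group, gives a 130-fold higher number from compound 2 to compound 4 (2.11 log units; beyond the scatter) in this assay, and the matching change from 4-methylpiperazin-1-yl gives a 170-fold higher number from compound 1 to compound 4 (2.24 log units; beyond the scatter). Changing only the outer group on the piperazine had given a 1.4-fold higher number from compound 1 to compound 2 (0.13 log units; within the scatter), so this position accepts either methyl or cyclobutyl on that ring, while the low numbers are lost once the ring itself is gone. Nothing measured here explains the size of this loss.

These compounds do not separate the loss of the ring from the loss of its outer nitrogen. A morpholine ring, or an open chain ending in an amine, would be needed to tell those two changes apart.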